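The source may hold more compounds than are shown below. What is called first, only, known or untested is meant among the compounds shown, and "the series" means these compounds.

Compound 1 `O=C(O)CCc1ccc(C#Cc2ccnc(-c3ccccc3)c2)cc1` gives 97% in an in vitro functional assay on 1321-N1 cells for agonist activity at Free fatty acid receptor 1 (Homo sapiens), read by fluorescence, spectrophotometry and calcium flux; a higher number here means a larger maximal response, a lower number a smaller maximal response.
Compound 2 `O=C(O)CCc1ccc(C#Cc2ccnc(F)c2)cc1` gives 98% in this assay.
Compound 3 `O=C(O)CCc1ccc(C#Cc2ccnc(Cl)c2)cc1` gives 94% in this assay.

Compound 3 stands level with the other two: a number 3 percentage points lower from compound 1 to compound 3 (within the scatter) and a number 4 percentage points lower from compound 2 to compound 3 (within the scatter), so the three maximal responses cannot be told apart. Compound 4 `COc1cc(C#Cc2ccc(CCC(=O)O)cc2)ccn1` differs from compound 3 at the same position where the other swaps were made: methoxy in place of chloro on an aromatic carbon. Among the measured compounds shown here, the steps that bear on this are a number 1 percentage points higher from compound 1 to compound 2 (within the scatter), a number 3 percentage points lower from compound 1 to compound 3 (within the scatter) and a number 4 percentage points lower from compound 2 to compound 3 (within the scatter); each exchanged one group at this carbon for another, and none moved the maximal response beyond the scatter. A methoxy group has not been tested at this place, but on these three exchanges no step beyond the scatter is expected in this assay. The estimate for compound 4 is therefore 95%, within 85% to 105%, meaning an expected step of a number 1 percentage points higher from compound 3 to compound 4 (within the scatter).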

Compound 4, largest response reached (reported as efficacy), in percent of the reference or control that the assay uses: 98%
Beside the measured number, compound 4's estimate is 3 percentage points below it, and the stated range covers the measured number.
By their numbers in this assay, from the lowest: compounds 3, 1, 2 and 4 (each within the scatter of the next).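

Methoxy brings a hydrogen-bond acceptor that chloro lacks, yet this assay shows a number 4 percentage points higher from compound 3 to compound 4 (within the scatter) and no change at the digits printed from compound 2 to compound 4 (within the scatter) and a number 1 percentage points higher from compound 1 to compound 4 (within the scatter) with no step beyond the scatter. Phenyl, fluoro, chloro and methoxy on this aromatic carbon next to the ring nitrogen therefore give maximal responses that cannot be told apart, and this now includes a group attached through oxygen. Nothing available explains this flat result. On these data alone, whether an amine or a carboxylic acid on this carbon would keep the maximal response remains open. Maximal response also does not show how much compound is needed to reach it.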